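Cytotoxicity notes: from compound 1 toward compound 4

This account rests on a few compounds, and the source may have more. Where it says the series, first, only, none or still open, it means among the compounds named here.

compound 1 `CC1(C)CC(=O)N(c2cnn3c2CN(C(=O)Nc2cc(F)c(F)c(F)c2)C(C2CC2)C3)C1` — 115000 nM
compound 2 `C[C@H]1Cn2ncc(N3CC(c4ccccc4)CC3=O)c2CN1CC(=O)Nc1cc(F)c(F)c(F)c1` — > 2000 nM
compound 3 `O=C1CC(c2ccccc2)CN1c1cnn2c1CN(C(=O)Nc1cc(F)c(F)c(F)c1)C(Cc1ccccc1)C2` — > 2000 nM

Among the compounds with values here, in a toxicity assay on HepG2 2.2.15 cells (Homo sapiens) for cytotoxicity, read by CellTiter-Glo (a lower number here means that less compound is tolerated, a higher number that more compound is tolerated), compound 1 gives 115000 nM, the only actual number among the three values shown. For compound 2 the result is a limit of the assay, > 2000 nM. For compound 3 the result is likewise a limit, > 2000 nM; two of the three values sit at the limit of > 2000 nM in this assay, at which 2 of the 3 values shown sit. Compound 4 `O=C1CC(c2ccccn2)CN1c1cnn2c1CN(C(=O)Nc1cc(F)c(F)c(F)c1)C(C1CC1)C2` has not yet been measured in this assay . It differs from compound 1 in one place: 2-oxo-4-(pyridin-2-yl)pyrrolidin-1-yl in place of 4,4-dimethyl-2-oxopyrrolidin-1-yl on an aromatic carbon. Within the data shown here, no step between measured compounds is available to size this change, so the expectation rests on compound 1 alone. The step from compound 1 to compound 4 is expected to be a 1.9-fold lower number from compound 1 to compound 4 (0.28 log units; within the scatter), a moderate fall, possibly within the scatter. Compound 4 is therefore expected to give about 60000 nM, within 20000 nM to 150000 nM.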

Compound 4, half-maximal cytotoxic concentration: 96200 nM
Estimate against measurement, compound 4: 1.6-fold (0.21 log units) below; the range from low to high includes it.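

In this assay, 2-oxo-4-(pyridin-2-yl)pyrrolidin-1-yl in place of 4,4-dimethyl-2-oxopyrrolidin-1-yl on this aromatic carbon gives a 1.2-fold lower number from compound 1 to compound 4 (0.08 log units; within the scatter). Within the data shown here, this is the first readable step, and it shows that the larger group, with its added pyridine ring, leaves the read-out within the scatter at this position. No measured property bears on the cause of this result.

Going by these compounds, whether an amine or a carboxylic acid at this position would behave the same stays open. Steps involving compound 2 and compound 3 cannot be read, as each value is a limit of the assay: the limit of > 2000 nM in this assay, at which 2 of the 4 values shown sit.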